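Adding a Second Chloro Group to Compound 3

The compounds below may be only part of what the source reports. "The series", "measured", "known", "first", "only" and "open" are said of these compounds alone.

Going by the values given here, compound 3 `Oc1cc(O)cc(OCc2cccc(Cl)c2)c1` is the only compound in this set with a numerical result: in an assay on B16 cells for inhibition of Tyrosinase (Mus musculus) (a higher number here means a weaker inhibitor, a lower number a stronger inhibitor), compound 3 gives 54700 nM, a weak inhibitor. Compound 1 `Oc1cc(OCc2ccc(Cl)c(Cl)c2)cc(OCc2ccc(Cl)c(Cl)c2)c1` was run in this assay and for compound 1 the entry reads "not determined" (no result reported); compound 2 `Oc1cc(OCc2cccc(Cl)c2)cc(OCc2cccc(Cl)c2)c1` was run in this assay and for compound 2 the entry reads "not determined" (no result reported), leaving nothing to compare with compound 3. Compound 4 `Oc1cc(O)cc(OCc2ccc(Cl)c(Cl)c2)c1` differs from compound 3 in one place: chloro in place of hydrogen on an aromatic carbon, a chloro in place of hydrogen on an aromatic carbon, ortho to a chloro group already present. Among the compounds with values here, no measured pair shows what such a change does here. The expected step is a 1.4-fold lower number from compound 3 to compound 4 (0.14 log units; within the scatter) in this assay, barely beyond the usual scatter. Compound 4 is estimated to give about 40000 nM in this assay, with a likely range from 15000 nM to 120000 nM.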

Compound 4, half-maximal inhibitory concentration: 66400 nM
Beside the measured number, compound 4's estimate is 1.7-fold (0.22 log units) below it; the range from low to high includes it.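

Going by these compounds alone, the pair gives a 1.2-fold higher number from compound 3 to compound 4 (0.08 log units; within the scatter) in this assay, the only direct look at this change. A chloro in place of hydrogen on this aromatic carbon, ortho to a chloro group, therefore leaves the read-out within what repeat measurements alone could produce. No data at hand offer an explanation for this result. Going by these compounds, whether an amine or a carboxylic acid on the same carbon would shift the number remains open. Compound 1 and compound 2 have no numerical result, so any steps involving them cannot be read.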